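The source may hold more compounds than are shown below. What is called first, only, known or untested is meant among the compounds shown, and "the series" means these compounds.

Two measured compounds share a common core and differ only in one group on it. Compound 1 `CCCCNc1nc(N)nc2cc(C(N)=O)ccc12` carries a carboxamide there; in an ADME assay on HEK293 cells for agonist activity at Toll-like receptor 8 (Homo sapiens), read by a luciferase reporter, with a stated time of 6 h (on this read-out lower numbers stand for an effect already at smaller amounts and higher numbers for an effect only at larger amounts of compound), compound 1 gives 2 uM. Compound 2 `CCCCNc1nc(N)nc2ccc(OC)cc12` carries a methoxy group instead; in this assay compound 2 gives 1.8 uM. Of the two numbers, compound 2 holds the lower one, but its gap to compound 1 lies within the scatter, so the two compounds cannot be told apart on these data.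

Compound 3 `CCCCNc1nc(N)nc2ccc(CCc3ccccn3)cc12` has not yet been measured. Relative to compound 2 it differs in one place: 2-(pyridin-2-yl)ethyl in place of methoxy on an aromatic carbon. Among the measured compounds shown here, no measured pair shows a change of this kind, so any expectation rests on the structures alone. The group that leaves and the group that enters each carry one hydrogen-bond acceptor, while the entering group brings an aromatic ring and a longer chain. The step of a 3.0-fold lower number from compound 2 to compound 3 (0.48 log units; beyond the scatter) is expected to be a modest gain, though it could just as well stay within the scatter. The value expected for compound 3 is 0.6 uM, with a range from 0.15 uM to 3 uM.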

Compound 3, minimum effective concentration: 0.3 uM
The estimate for compound 3 lay 2.0-fold (0.30 log units) above the measured number, within the range that was stated.
By their numbers in this assay, from the lowest: compound 3; then compounds 2 and 1 (each within the scatter of the next).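

In this assay, putting 2-(pyridin-2-yl)ethyl in place of methoxy gives a 6.0-fold lower number from compound 2 to compound 3 (0.78 log units; beyond the scatter), a step beyond the scatter towards an effect at smaller amounts of compound. Until this result, the position had shown only methoxy, so there was no sign of how it would respond to a much larger group; now it is clear that a group with a two-carbon chain and a six-membered aromatic ring is not only accepted here but also gives the lowest number of the series. Nothing in the data at hand offers a reason for this step.

The compounds shown leave open which part of the entering group matters: the ring nitrogen, the aromatic ring or simply the chain. A 2-phenylethyl group, with carbon in place of the ring nitrogen, would test the first of these, a plain butyl chain with no ring would test the other two, and a longer chain leading to the same pyridine ring would show whether the distance from the shared core counts.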